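From Ethoxy to Isobutoxy on a Shared Core

The compounds below may be only part of what the source reports. "The series", "measured", "known", "first", "only" and "open" are said of these compounds alone.

In a functional assay on A549 cells (Homo sapiens) for cytotoxicity (on this read-out higher numbers stand for an effect only at larger amounts of compound and lower numbers for an effect already at smaller amounts), compound 1 (`CCOc1cc(-c2ccccc2)nc2ccccc12`) gives > 10 ug/mL, which is a limit of the assay and not a number. In the same assay, compound 2 (`Oc1cc(-c2ccccc2)nc2ccc(Cl)cc12`) gives 0.51 ug/mL and compound 3 (`COc1ccc2nc(-c3ccccc3)cc(O)c2c1`) gives 0.19 ug/mL. Compound 4 (`CC(C)COc1cc(-c2ccccc2)nc2ccccc12`) differs from compound 1 by isopropyl in place of methyl on a saturated chain carbon bound to an oxygen on an aromatic ring, or ethoxy to isobutoxy when cut one bond further out. For the measured compounds named here, the only measured step, a 2.7-fold lower number from compound 2 to compound 3 (0.43 log units; beyond the scatter), is a modest one, with methoxy in place of chloro on an aromatic carbon, and it does not touch this chain. It therefore gives little guidance on size or direction. The expectation rests mainly on compound 1, which stands at the limit of > 10 ug/mL in this assay, at which 1 of the 3 values shown sits. A step that the limit leaves unreadable from compound 1 to compound 4 is expected, which amounts to no change beyond the scatter in this assay. Compound 4 is estimated at 14 ug/mL, within an expected range of 5 ug/mL to 30 ug/mL.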

Compound 4, half-maximal effective concentration: > 10 ug/mL
Compound 4 ended at the assay's limit; the forecaster's own chance of this, stated with the estimate: 75%; the middle value does not contradict the limit.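

Compound 4 gives > 10 ug/mL, which is a limit of the assay and not a number. Compound 1 gives > 10 ug/mL, likewise a limit. For the compounds shown here, no step from compound 1 to compound 4 can therefore be read: the limit of > 10 ug/mL in this assay, at which 2 of the 4 values shown sit. The compounds shown leave open whether ethoxy to isobutoxy on the shared core changes the read-out at all.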